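From hydroxyamino to hydroxy on a carbonyl carbon

The source may hold more compounds than are shown below. What is called first, only, known or untested is meant among the compounds shown, and "the series" means these compounds.

Measured so far:
- Compound 1 `O=C(N[C@H]1CC[C@]2(CC1)OC[C@]1(O2)C2CC3CC(C2)CC1C3)c1ccc(O)c(O)c1`: > 50000 nM (a limit)
- Compound 2 `O=C(NO)[C@H]1CC[C@@]2(CC1)OC[C@]1(OO2)C2CC3CC(C2)CC1C3`: > 50000 nM (a limit)

Both compounds were tested in an ADME assay on L02 cells (Homo sapiens) for cytotoxicity, read by MTT assay, with a stated time of 48 h; on this read-out lower numbers stand for stronger inhibition and higher numbers for weaker inhibition. Compound 2 gives no number here, since its > 50000 nM is a limit of the assay. The data so far show only (the limit of > 50000 nM in this assay, at which 2 of the 2 values shown sit).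

Compound 3 `O=C(O)[C@H]1CC[C@@]2(CC1)OC[C@]1(OO2)C2CC3CC(C2)CC1C3` differs from compound 2 in one place: hydroxy in place of hydroxyamino on a carbonyl carbon. Hydroxy stands in place of hydroxyamino on a carbonyl carbon. Among the compounds with values here, no measured pair shows what this change does in this assay. The expectation therefore rests on compound 2 at > 50000 nM, and no step beyond the scatter is expected in either direction. The expected step that the limit leaves unreadable from compound 2 to compound 3 is small. For compound 3 the estimated value is 70000 nM, with an expected range of 35000 nM to 150000 nM.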

Compound 3, half-maximal inhibitory concentration: > 100000 nM
Compound 3 gave a limit, no number; the forecaster's own chance of this, stated with the estimate: 85%; middle value at least 1.4-fold (0.15 log units) away from the limit.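

In this assay compound 3 gives > 100000 nM, which is a limit and not a number. Compound 2 also stands at a limit, so no step can be read between compound 2 and compound 3. The compounds shown leave open what hydroxy in place of hydroxyamino on a carbonyl carbon does in this assay.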